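The compounds below may be only part of what the source reports. "The series", "measured", "known", "first", "only" and "open" are said of these compounds alone.

Measured compounds:
compound 1, `CCN(C)C(=O)[C@H]1C[C@@H](C(=O)N2CCC[C@H]2C#N)N[C@H]1C`: 79%
compound 2, `C[C@@H]1N[C@H](C(=O)N2CCC[C@H]2C#N)C[C@@H]1C(=O)N1CCOCC1`: 85%

Among the measured compounds shown here, in an assay on the whole organism (plasma, strain Sprague-Dawley) for inhibition of Dipeptidyl peptidase 4 (Rattus norvegicus), with a stated time of 10 h, at a dose of 1 mg/kg by the oral route (on this read-out lower numbers stand for less inhibition and higher numbers for more inhibition at the one dose given (going by the name of the read-out)), compound 2 holds the upper of the two numbers, but its only neighbour, compound 1, sits close by: the step of a number 6 percentage points higher from compound 1 to compound 2 (within the scatter) is within the scatter, so the two are not told apart.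

Compound 3, `C[C@@H]1N[C@H](C(=O)N2CCC[C@H]2C#N)C[C@@H]1C(=O)N1CCCC1`, follows from compound 2 by one change: pyrrolidin-1-yl in place of morpholin-4-yl on a carbonyl carbon.

For the measured compounds named here, one measured step bears on this, the exchange of one amine on the same carbonyl carbon for another, from compound 1 to compound 2, which gave a number 6 percentage points higher from compound 1 to compound 2 (within the scatter) and stayed within the scatter. Nothing here suggests that a second exchange of this kind would move the read-out farther. Compound 3 is therefore expected to sit near compound 2, with a step of about a number 3 percentage points lower from compound 2 to compound 3 (within the scatter) and no movement beyond the scatter. The estimate for compound 3 is 82%, expected between 66% and 94%.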

Compound 3, a percentage reported as inhibition, in the whole organism at one dose (the size of the read-out at that dose, not a potency): 88%
The estimate for compound 3 lay 6 percentage points below the measured number; low and high end bracket the measured number.
By their numbers in this assay, from the lowest: compounds 1, 2 and 3 (each within the scatter of the next).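

In this assay, pyrrolidin-1-yl in place of morpholin-4-yl on the carbonyl carbon gives a number 3 percentage points higher from compound 2 to compound 3 (within the scatter), and pyrrolidin-1-yl in place of ethyl(methyl)amino gives a number 9 percentage points higher from compound 1 to compound 3 (within the scatter). This position has now carried an open-chain amine, a six-membered ring with 2 hetero atoms and a five-membered ring with 1 hetero atom, and the three compounds are not told apart at this one dose, so the exchange of amines on this carbonyl carbon has so far produced no step beyond the scatter. Nothing at hand accounts for this result.

On these data alone, it remains open whether a piperazine ring or a longer chain on the same carbonyl carbon would also stay within the scatter. As far as these compounds go, it is equally open whether a carboxylic acid in place of the amide would do so.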